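Replacing Methoxyphenyl with Bromo-Chlorophenyl on the Shared Core

The source may report more compounds than this note shows. Statements on the series, on what has been measured and on what is new or still open speak of the compounds shown alone.

Three compounds have been measured in a functional assay on MV4-11 cells (Homo sapiens) for inhibition, with a stated time of 120 h, tested at 10 uM; a higher number here means more inhibition at the concentration tested (going by the name of the read-out), a lower number less inhibition:

compound 1 `Cc1n[nH]c2ccc(-c3nc4cnc(N5CCN(C)CC5)cn4c3Nc3ccccc3F)cc12` gives 0%
compound 2 `Cc1n[nH]c2ccc(-c3nc4cnc(N5CCN(C)CC5)cn4c3Nc3cccc(F)c3)cc12` gives 18.5%
compound 3 `COc1ccc(Nc2c(-c3ccc4[nH]nc(C)c4c3)nc3cnc(N4CCN(C)CC4)cn23)cc1` gives 3.32%

All three share one core and differ only in the ring attached to a nitrogen on that core. Compound 3 holds the second highest of the three numbers. The step of a number 3.3 percentage points higher from compound 1 to compound 3 (within the scatter) lies within the scatter, so compound 1 and compound 3 cannot be told apart, whereas the step of a number 15.2 percentage points lower from compound 2 to compound 3 (beyond the scatter) lies beyond it.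

Compound 4 `Cc1n[nH]c2ccc(-c3nc4cnc(N5CCN(C)CC5)cn4c3Nc3ccc(Br)cc3Cl)cc12` differs from compound 3 in one place: 4-bromo-2-chlorophenyl in place of 4-methoxyphenyl on a nitrogen on an aromatic ring. The two measured steps that bear on this are the swaps at the same nitrogen, a number 3.3 percentage points higher from compound 1 to compound 3 (within the scatter) and a number 15.2 percentage points lower from compound 2 to compound 3 (beyond the scatter), both of modest size. Neither involved a bromine or chlorine, so the direction is uncertain; a step of modest size in either direction is expected in this assay, a number 6.7 percentage points higher from compound 3 to compound 4 (within the scatter).

Compound 4 is therefore estimated to give about 10%, ranging from 0% to 35%.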

Compound 4, a percentage reported as inhibition, at one concentration (the size of the read-out at that concentration, not a potency): 70.5%
Compound 4: the middle estimate sits 60.5 percentage points below what was measured; measured number above the stated range.
By their numbers in this assay, from the lowest: compounds 1 and 3 (each within the scatter of the next); then compound 2; then compound 4.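

At this nitrogen, the choice of ring can move the result in this assay much further than the earlier swaps showed: 4-bromo-2-chlorophenyl brings a number 67.2 percentage points higher from compound 3 to compound 4 (beyond the scatter) and a number 52 percentage points higher from compound 2 to compound 4 (beyond the scatter) and also a number 70.5 percentage points higher from compound 1 to compound 4 (beyond the scatter) and each of these steps is large. Among the compounds shown here, compound 4 is also the only one of the four compounds with bromine or chlorine on this ring, so halogens other than fluorine go with the highest number here, though one compound sets no pattern. Nothing measured here explains the size of this jump.

On these data alone, compound 4 carries both halogens at once, so it remains open whether 4-bromophenyl or 2-chlorophenyl alone would give a similar number. As far as these compounds go, the read-out comes from one concentration and gives no potency, so how compound 4 behaves at lower concentrations also remains open.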